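Swapping Chlorine for Fluorine on the Anilino Ring

This account rests on a few compounds, and the source may have more. Where it says the series, first, only, none or still open, it means among the compounds named here.

This piece follows a small change made to compound 1 `O=C1C(Nc2cccc(Cl)c2)=CC(=O)c2c1nc1n2[C@H]2OC[C@@H](O)[C@H]2OC1`, which carries a (3-chlorophenyl)amino group on the shared core. In a functional assay on MGC-803 cells (Homo sapiens) for inhibition, read by sulforhodamine B assay (on this read-out higher numbers stand for weaker inhibition and lower numbers for stronger inhibition), compound 1 gives 1530 nM. Compound 2 `CCCc1ccc(NC2=CC(=O)c3c(nc4n3[C@H]3OC[C@@H](O)[C@H]3OC4)C2=O)cc1`, bearing a 4-propylphenyl group on the same amine nitrogen, gives 1920 nM in this assay; the step of a 1.3-fold higher number from compound 1 to compound 2 (0.10 log units; within the scatter) lies within the scatter, so the two cannot be ordered. Compound 3 `O=C1C=C(NC2CCCC2)C(=O)c2c1nc1n2[C@H]2OC[C@@H](O)[C@H]2OC1`, with a cyclopentyl group on that nitrogen, is reported in this assay only as a limit, > 8000 nM; this is the limit of > 8000 nM in this assay, at which 1 of the 3 values shown sits. Of the two numbers shown, compound 1 holds the lower one, with compound 2 within the scatter of it.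

Compound 4 `O=C1C(Nc2cccc(F)c2)=CC(=O)c2c1nc1n2[C@H]2OC[C@@H](O)[C@H]2OC1` differs from compound 1 by fluoro in place of chloro on an aromatic carbon. No measured step exchanges one halogen for another; the only single-place step shown, from compound 1 to compound 2, replaces the whole group on the nitrogen and stays within the scatter. The expected step of a 1.2-fold higher number from compound 1 to compound 4 (0.07 log units; within the scatter) is therefore small, with no clear direction. Compound 4 is estimated at 1800 nM, in a range from 900 nM to 4000 nM.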

Compound 4, half-maximal inhibitory concentration: 1470 nM
The estimate for compound 4 lay 1.2-fold (0.09 log units) above the measured number, and the stated range covers the measured number.
By their numbers in this assay, from the lowest: compounds 4, 1 and 2 (each within the scatter of the next). At a limit, above all of these: compound 3.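

Chloro and fluoro at this place on the ring cannot be told apart in this assay, as the exchange gives only a small step (a 1.0-fold lower number from compound 1 to compound 4 (0.02 log units; within the scatter)). Compound 4 also cannot be told apart from the compound with the much larger 4-propylphenyl group on the nitrogen (a 1.3-fold lower number from compound 2 to compound 4 (0.12 log units; within the scatter)), so compounds 1, 2 and 4 now form a group of three that sit within the scatter of one another. The data shown offer no measured reason why these substituents read alike.

Going by these compounds, whether bromo, methoxy, an amine or a carboxylic acid at this place on the ring would also stay within the scatter remains open. So does what a longer chain than propyl would give.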